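Moving the pyridine nitrogen in a hydrazone cytotoxicity series

The source may hold more compounds than are shown below. What is called first, only, known or untested is meant among the compounds shown, and "the series" means these compounds.

Compound 1, `Cc1c(/C=N/NC(=O)c2ccncc2)no[n+]1[O-]`, gives > 400000 nM in an ADME assay on J774.1 cells (Mus musculus) for cytotoxicity, read by MTT assay, with a stated time of 48 h; on this read-out lower numbers stand for stronger inhibition and higher numbers for weaker inhibition; this value is a limit of the assay, not a number.
Compound 2, `Cc1c(C(=O)N/N=C/c2cccs2)ns[n+]1[O-]`, gives > 400000 nM in this assay; this too is a limit of the assay.
Compound 3, `COc1ccc(/C=N/NC(=O)c2no[n+]([O-])c2C)cc1O`, gives > 400000 nM in this assay; again a limit of the assay.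

So compound 1 stands nowhere in particular on these numbers: its own result is only a limit, and the two other results shown are limits as well, so that the limit of > 400000 nM in this assay, at which 3 of the 3 values shown sit, describes every value that is available. Within the data shown here, no pair of measured compounds differs in one place, and no step of a known size can be drawn from them.

Compound 4, `Cc1c(/C=N/NC(=O)c2cccnc2)no[n+]1[O-]`, is the one still to be measured. It differs from compound 1 in a single way: pyridin-3-yl in place of pyridin-4-yl on a carbonyl carbon. The atoms are the same; only the point at which the pyridine ring joins the carbonyl carbon moves.

Because compound 1 sits at the limit of > 400000 nM in this assay, at which 3 of the 3 values shown sit, the step of a number no higher from compound 1 to compound 4 (the limit leaves the size open) is expected to be none beyond the scatter, and a limit rather than a number is the most probable outcome. For compound 4 the estimate in this assay is 400000 nM, expected to fall between 200000 nM and 800000 nM.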

Compound 4, half-maximal inhibitory concentration: > 400000 nM
Compound 4: only a limit was reported; the forecaster's own chance of this, stated with the estimate: 85%; the middle value sits exactly at the limit.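

The step from compound 1 to compound 4 cannot be read in this assay, because both results are limits of the assay and not numbers: the limit of > 400000 nM in this assay, at which 4 of the 4 values shown sit.

The compounds shown leave open how strongly any of them acts on these cells, and whether pyridin-3-yl and pyridin-4-yl on a carbonyl carbon differ at all.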